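The compounds below may be only part of what the source reports. "The series", "measured", "known", "first", "only" and "open" are said of these compounds alone.

In a physicochemical assay for solubility (a lower number here means a less soluble compound, a higher number a more soluble compound), the measured compounds read:
compound 1 `CN(C)CC(=O)N1CCC(NS(=O)(=O)c2cc(S(=O)(=O)c3ccccc3)ccc2C(F)(F)F)CC1` gives 100000 nM
compound 2 `CC(C)(C)OC(=O)N1CCC[C@@H]1C(=O)N1CCC(NS(=O)(=O)c2cc(S(=O)(=O)c3ccccc3)ccc2C(F)(F)F)CC1` gives 25000 nM
compound 3 `CN(C)CC(=O)N1CCC[C@H]1C(=O)N1CCC(NS(=O)(=O)c2cc(S(=O)(=O)c3ccccc3)ccc2C(F)(F)F)CC1` gives 100000 nM

Compound 3 stands level with compound 1, and together they hold the highest number of the three. Compound 4 `CN(C)C(=O)N1CCC[C@H]1C(=O)N1CCC(NS(=O)(=O)c2cc(S(=O)(=O)c3ccccc3)ccc2C(F)(F)F)CC1` differs from compound 3 by dimethylamino in place of (dimethylamino)methyl on a carbonyl carbon with dimethylamino in place of (dimethylamino)methyl on a carbonyl carbon. Within the data shown here, no measured step makes this exact change. The nearest evidence is no change at the digits printed from compound 1 to compound 3 (within the scatter) on one side, and on the other 4.0-fold lower number from compound 1 to compound 2 (0.60 log units; beyond the scatter) and a 4.0-fold higher number from compound 2 to compound 3 (0.60 log units; beyond the scatter) as modest steps tied to compound 2 and its tert-butoxycarbonyl group. No step beyond the scatter is therefore expected, and the expected step is a 1.1-fold lower number from compound 3 to compound 4 (0.05 log units; within the scatter) in this reading. Compound 4 is estimated at 90000 nM with 40000 nM to 150000 nM as the expected range.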

Compound 4, solubility: 100000 nM
Beside the measured number, compound 4's estimate is 1.1-fold (0.05 log units) below it; the range from low to high includes it.
By their numbers in this assay, from the lowest: compound 2; then compounds 1, 3 and 4 (each within the scatter of the next).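

In this assay, the shorter dimethylamino group on the carbonyl carbon holds the reading of the (dimethylamino)methyl group, with no change at the digits printed from compound 3 to compound 4 (within the scatter). The 1-(dimethylcarbamoyl)pyrrolidin-2-yl group likewise matches the plain (dimethylamino)methyl group, with no change at the digits printed from compound 1 to compound 4 (within the scatter), whereas putting it in place of 1-(tert-butoxycarbonyl)pyrrolidin-2-yl gives a 4.0-fold higher number from compound 2 to compound 4 (0.60 log units; beyond the scatter). Nothing measured here accounts for these readings. The compounds shown leave open whether a carboxylic acid or a longer chain on this carbonyl carbon would keep the same reading in this assay.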